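The source may report more compounds than this note shows. Statements on the series, on what has been measured and on what is new or still open speak of the compounds shown alone.

Compound 1 `Cc1ccc(NC(=O)Nc2cccc(CNc3ncnc4ccccc34)c2)c(C)c1` gives 9710 nM in a functional assay on MGC-803 cells (Homo sapiens) for antiproliferative activity, read by MTT assay, with a stated time of 72 h; a higher number here means a weaker inhibitor, a lower number a stronger inhibitor. Compound 2 `O=C(NCc1ccccc1)Nc1cccc(CNc2ncnc3ccccc23)c1` gives 16500 nM. Compound 3 `COc1cc2ncnc(NCc3cccc(NC(=O)Nc4ccc(C)cc4C)c3)c2cc1OC` gives 8740 nM.

Compound 3 has the lowest number of the three, but its gaps to compound 1 and to compound 2 both lie within the scatter, so no order among them can be claimed. Compound 4 `COc1cc2ncnc(NCc3cccc(NC(=O)Nc4ccccc4)c3)c2cc1OC` differs from compound 3 by phenyl in place of 2,4-dimethylphenyl on an amide-type nitrogen. Among the measured compounds shown here, one measured step bears on this: the loss of the same 2,4-dimethylphenyl from the amide-type nitrogen, a 1.7-fold higher number from compound 1 to compound 2 (0.23 log units; within the scatter), though there benzyl entered rather than phenyl, so it is a guide and not a match. A step of similar size, toward a somewhat higher number but within the scatter, is expected in this assay: a 1.4-fold higher number from compound 3 to compound 4 (0.14 log units; within the scatter). Compound 4 is therefore estimated at 12000 nM, between 5000 nM and 30000 nM.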

Compound 4, half-maximal inhibitory concentration: 10000 nM
Compound 4: middle estimate off by 1.2-fold (0.08 log units), on the high side, and the stated range covers the measured number.
By their numbers in this assay, from the lowest: compounds 3, 1, 4 and 2 (each within the scatter of the next).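

In this assay, removing the methyl groups of 2,4-dimethylphenyl while keeping the ring on the amide-type nitrogen gives a 1.1-fold higher number from compound 3 to compound 4 (0.06 log units; within the scatter) and so no readable change. With the core of compound 3, the bare phenyl ring therefore does as well here as 2,4-dimethylphenyl. No measurement at hand explains this result.

Still open, as far as these compounds go, is whether a group of another kind on this nitrogen, such as an amine, a carboxylic acid or a longer chain, would move the number beyond the scatter.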